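Urea aryl swap: working notes on compounds 1 to 3

This account rests on a few compounds, and the source may have more. Where it says the series, first, only, none or still open, it means among the compounds named here.

Measured in a functional assay on PC-3 cells (Homo sapiens) for inhibition, with a stated time of 72 h; a higher number here means a weaker inhibitor, a lower number a stronger inhibitor:
compound 1, `Cc1cc(Cl)ccc1NC(=O)Nc1nc(Sc2c[nH]c3ccccc23)cc(N2CCN(Cc3ccccc3)CC2)n1`, 22500 nM
compound 2, `O=C(Nc1ccccc1)Nc1nc(Nc2ccccc2)cc(Sc2c[nH]c3ccccc23)n1`, 26400 nM

Both measured compounds sit in the same region. Compound 1 stands level with compound 2 in this assay; the gap between them lies within the scatter, so neither is set apart, and the two differ in more than one place, so no single step can be read from them.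

Compound 3, `Cc1ccc(C)c(NC(=O)Nc2nc(Sc3c[nH]c4ccccc34)cc(N3CCN(Cc4ccccc4)CC3)n2)c1`, is not yet measured. It differs from compound 1 by 2,5-dimethylphenyl in place of 4-chloro-2-methylphenyl on an amide-type nitrogen. Going by the values given here, no step between measured compounds covers this change, so nothing measured here speaks for a move in either direction. With the two measured numbers so close, the expectation for compound 3 in this assay is a step no larger than the scatter, a 1.1-fold higher number from compound 1 to compound 3 (0.03 log units; within the scatter). Compound 3 is therefore estimated at 24000 nM, with a range from 8000 nM to 70000 nM.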

Compound 3, half-maximal inhibitory concentration: 17300 nM
The estimate for compound 3 lay 1.4-fold (0.14 log units) above the measured number; the measured number falls inside the stated range.
By their numbers in this assay, from the lowest: compounds 3, 1 and 2 (each within the scatter of the next).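

In this assay, going by these compounds alone, the exchange of 4-chloro-2-methylphenyl for 2,5-dimethylphenyl on the amide-type nitrogen gives a 1.3-fold lower number from compound 1 to compound 3 (0.11 log units; within the scatter) and so supplies the first single-place step. At this position, with the rest of compound 1 held constant, the two aryl groups are not set apart: replacing the chlorine-bearing group with the all-carbon group of equal heavy-atom count leaves the number within the scatter. Nothing available explains this step or tests what lies behind it.

The compounds shown cover only a narrow range of aryl groups at this position, so they do not show whether any group there can move the number beyond the scatter. Going by these compounds, whether a carboxylic acid or an aminomethyl group on this ring would do so remains open.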